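Coumarin ethers on colon cancer cells: nitro for acetamido

A few compounds are considered here, and "the series" means these few. Any claim that something is new, unique, unknown or untested is made for them only; others in the source may bear on it.

Working notes. Going by the values given here, compound 1 `O=c1ccc2cc(OCc3cc(-c4ccc5ccccc5c4)no3)ccc2o1` is the only member with a number so far: in a functional assay on COLO 205 cells (Homo sapiens) for cytotoxicity, read by MTT assay, with a stated time of 48 h (a lower number here means a stronger inhibitor, a higher number a weaker inhibitor), compound 1 gives 48700 nM, a weak result. Compound 2 `CC(=O)Nc1ccc(-n2cc(COc3ccc4oc(=O)ccc4c3)nn2)cc1` shares the core of compound 1 with a different side group; in this assay compound 2 gives "not determined" (no result reported), so no number places compound 2 on the scale and nothing can be said of how it compares with compound 1. Compound 3 `O=c1ccc2cc(OCc3cn(-c4ccc([N+](=O)[O-])cc4)nn3)ccc2o1` differs from compound 2 in one place: nitro in place of acetamido on an aromatic carbon. Among the compounds with values here, no step between measured compounds is available, so no size or direction beyond the usual scatter in this assay can be read from the series for this change; the only anchor is the weak result of compound 1. Compound 3 is therefore expected to give 40000 nM, with a range of 10000 nM to 100000 nM. A reported limit rather than a number is a real possibility.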

Compound 3, half-maximal inhibitory concentration: 48700 nM
The estimate for compound 3 lay 1.2-fold (0.09 log units) below the measured number; low and high end bracket the measured number.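

No new step can be read: compound 2 carries no number in this assay to set against compound 3. The compounds shown leave open how nitro in place of acetamido bears on this cytotoxicity. No supporting observation bears on the result.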